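The compounds below may be only part of what the source reports. "The series", "measured", "known", "first", "only" and "open" are said of these compounds alone.

In a functional assay on LOX IMVI cells (Homo sapiens) for cytotoxicity, read by MTT assay, with a stated time of 24 h (on this read-out lower numbers stand for stronger inhibition and higher numbers for weaker inhibition), compound 1 (`COc1cc(-c2nc(-c3ccccc3)[nH]c2-c2ccnc(NCCCNS(=O)(=O)c3ccc(F)cc3)n2)ccc1F`) gives 3960 nM and compound 2 (`COc1cc(-c2nc(-c3ccccc3)[nH]c2-c2ccnc(NCCCNS(=O)(=O)c3ccc(C)cc3)n2)ccc1F`) gives 2590 nM so the two stand within the scatter of each other. That single measured step (a 1.5-fold lower number from compound 1 to compound 2 (0.18 log units; within the scatter)) is methyl in place of fluoro on an aromatic carbon, a different change from the one at issue here. Compound 3 (`O=S(=O)(NCCCNc1nccc(-c2[nH]c(-c3ccccc3)nc2-c2ccc(F)c(O)c2)n1)c1ccc(F)cc1`) differs from compound 1 by hydrogen in place of methyl on an oxygen on an aromatic ring, methoxy to hydroxy. For the measured compounds named here, no measured step covers this change, so in this assay no step beyond the scatter is expected. Compound 3 is estimated at 2800 nM with an expected range of 900 nM to 8000 nM for a measurement. The expected step reads (a 1.4-fold lower number from compound 1 to compound 3 (0.15 log units; within the scatter)).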

Compound 3, half-maximal inhibitory concentration: 19200 nM
Beside the measured number, compound 3's estimate is 6.9-fold (0.84 log units) below it; the measured number lies above the stated range.
By their numbers in this assay, from the lowest: compounds 2 and 1 (each within the scatter of the next); then compound 3.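

In this assay, replacing methoxy with hydroxy gives a 4.8-fold higher number from compound 1 to compound 3 (0.69 log units; beyond the scatter), the only step shown that lies beyond the scatter; the earlier change of methyl in place of fluoro stayed within it. The methyl on this oxygen therefore matters to this read-out, and removing it weakens inhibition. No available evidence accounts for this rise in the number. The compounds shown leave open whether an ethoxy group or an amine in place of the methoxy would keep the value of compound 1.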